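The compounds below may be only part of what the source reports. "The series", "measured", "known", "first", "only" and "open" are said of these compounds alone.

Measured compounds in a functional assay on T47D cells (Homo sapiens) for inhibition, read by sulforhodamine B assay, with a stated time of 48 h; on this read-out higher numbers stand for weaker inhibition of growth and lower numbers for stronger inhibition of growth:
- compound 1, `CC(=O)OC/C(=C\c1ccc(F)cc1)C(=O)c1ccccc1`: compound 1 gives 14000 nM
- compound 2, `CC(=O)OC/C(=C\c1ccccc1F)C(=O)c1ccccc1`: compound 2 gives 18000 nM
- compound 3, `C=C(C/C(=C\c1ccccc1)C(=O)c1ccccc1)C(=O)c1ccccc1`: compound 3 gives 15000 nM

Compound 3 stands second highest of the three numbers, yet its number lies within the scatter of compound 1 and of compound 2, so no order among the three can be read from these data. Within the data shown here, the only step between compounds that differ in one place, a 1.3-fold higher number from compound 1 to compound 2 (0.11 log units; within the scatter), is within the scatter: moving the fluoro from one ring position to another left the growth inhibition unchanged. Compound 1 and compound 3 differ in more than one place; their numbers are likewise within the scatter of each other.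

Compound 4, `C=C(C/C(=C\c1ccccc1F)C(=O)c1ccccc1)C(=O)c1ccccc1`, differs from compound 3 by fluoro in place of hydrogen on an aromatic carbon. Among the measured compounds shown here, no measured pair shows this particular change, fluoro in place of hydrogen on the same ring, directly; the measured step bearing on it concerns only where the fluoro sits, not its presence. With nothing in the series suggesting a fluoro changes the read-out, the step of a 1.1-fold higher number from compound 3 to compound 4 (0.03 log units; within the scatter) is expected to be small, with no direction beyond the scatter. Compound 4 is therefore estimated at 16000 nM, with a range from 8000 nM to 32000 nM.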

Compound 4, concentration for 50% growth inhibition: 14000 nM
For compound 4 the middle estimate is 1.1-fold (0.06 log units) above the measured one; the range from low to high includes it.
By their numbers in this assay, from the lowest: compounds 1, 4, 3 and 2 (each within the scatter of the next).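

Fluoro in place of hydrogen on this aromatic carbon, ortho to a large group, can now be read directly in this assay and comes out as a 1.1-fold lower number from compound 3 to compound 4 (0.03 log units; within the scatter) with the phenyl to 2-fluorophenyl change leaving growth inhibition unchanged on the core of compound 3. The earlier step, a 1.3-fold higher number from compound 1 to compound 2 (0.11 log units; within the scatter) on the core of compound 1, concerned only where the fluoro sits, whereas this step concerns its presence, and neither reading moves growth inhibition beyond the scatter. Nothing available bears on the reason for this flat result.

The compounds shown leave open whether a group other than fluoro on this ring, such as an amine or a carboxylic acid, would give a step beyond the scatter. As far as these compounds go, it also remains open whether a longer chain in place of the hydrogen at this aromatic carbon would separate from compound 3 in this assay or stay level with it, as the fluoro does.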